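A few compounds are considered here, and "the series" means these few. Any claim that something is new, unique, unknown or untested is made for them only; others in the source may bear on it.

Going by the values given here, compound 1 `Cc1ccc(Cn2cc(COc3ccc4c(=O)ccoc4c3)nn2)cc1` gives 68500 nM in a functional assay on QGY7701 cells (Homo sapiens) for cytotoxicity, read by MTT assay, with a stated time of 48 h (a higher number here means a weaker inhibitor, a lower number a stronger inhibitor), and has the lower of the two numbers so far, though compound 2 `O=c1ccoc2cc(OCc3cn(Cc4ccc(Br)cc4)nn3)ccc12`, with 96400 nM in this assay, sits within the scatter of it: the step of a 1.4-fold higher number from compound 1 to compound 2 (0.15 log units; within the scatter). Compound 3 `N#Cc1cccc(Cn2cc(COc3ccc4c(=O)ccoc4c3)nn2)c1` differs from compound 1 as follows: 3-cyanophenyl in place of 4-methylphenyl on a saturated chain carbon bound to an aromatic nitrogen. Among the compounds with values here, the only measured step also alters the group on the saturated chain carbon bound to an aromatic nitrogen and stayed within the scatter, so no step beyond the scatter is expected here either, a 1.1-fold higher number from compound 1 to compound 3 (0.02 log units; within the scatter). Compound 3 is therefore estimated at 72000 nM in this assay, within 30000 nM to 170000 nM.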

Compound 3, half-maximal inhibitory concentration: 24400 nM
The estimate for compound 3 lay 3.0-fold (0.47 log units) above the measured number; measured number outside the range, below it.
By their numbers in this assay, from the lowest: compound 3; then compounds 1 and 2 (each within the scatter of the next).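

On the saturated chain carbon bound to an aromatic nitrogen, the group can move the number beyond the scatter in this assay: 3-cyanophenyl gives (a 2.8-fold lower number from compound 1 to compound 3 (0.45 log units; beyond the scatter)) and (a 4.0-fold lower number from compound 2 to compound 3 (0.60 log units; beyond the scatter)). Both steps are modest, and compounds 1 and 2 stay within the scatter of each other, so only this replacement separates itself so far. No available evidence bears on this result.

The nitrile and its place on the ring change together, so their contributions cannot be separated. On these data alone, whether an amine, a carboxylic acid or a longer chain at this position would move the number further remains open.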